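Iodophenyl for Pyridyl on Two Hydrazone Cores

The source may report more compounds than this note shows. Statements on the series, on what has been measured and on what is new or still open speak of the compounds shown alone.

Measured so far:
compound 1 `O=C(N/N=C/C1=C(Cl)c2ccccc2CCC1)c1cccnc1` — 91700 nM
compound 2 `O=C(N/N=C/C1=C(Cl)c2ccccc2CCC1)c1cccc(I)c1` — 55200 nM
compound 3 `Cc1cc2c(cc1C)C(Cl)=C(/C=N/NC(=O)c1cccnc1)CCC2` — 5400 nM

Of the compounds shown here, three have been measured in a functional assay on MDA-MB-231 cells (Homo sapiens) for inhibition, read by sulforhodamine B assay, with a stated time of 48 h; on this read-out lower numbers stand for stronger inhibition of growth and higher numbers for weaker inhibition of growth. Compound 1 and compound 2 share one core and differ by the change (3-iodophenyl in place of pyridin-3-yl on a carbonyl carbon). The step of a 1.7-fold lower number from compound 1 to compound 2 (0.22 log units; within the scatter) is within the scatter, so the two values cannot be told apart with confidence. Compound 3 carries a second core; how the core of compound 3 differs from the core of compound 1 is not broken down here. In this assay compound 3 gives 5400 nM, which stands beyond the scatter from both compound 1 and compound 2.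

Compound 4 `Cc1cc2c(cc1C)C(Cl)=C(/C=N/NC(=O)c1cccc(I)c1)CCC2` has not yet been measured. Within the data shown here, it differs from compound 3 by 3-iodophenyl in place of pyridin-3-yl on a carbonyl carbon, and since the place is the same word for word, this is the same change as the one from compound 1 to compound 2. On the first core that change gave a step within the scatter, so on the second core a step of about the same small size is expected, that is a 1.6-fold lower number from compound 3 to compound 4 (0.21 log units; within the scatter), an expectation that rests on compound 3 with its value 5400 nM and on the step of a 1.7-fold lower number from compound 1 to compound 2 (0.22 log units; within the scatter). Compound 4 is therefore estimated at 3300 nM in this assay, expected to fall between 1200 nM and 9000 nM.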

Compound 4, concentration for 50% growth inhibition: 1200 nM
Beside the measured number, compound 4's estimate is 2.8-fold (0.44 log units) above it; measured number inside the range.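

In this assay, putting 3-iodophenyl in place of pyridin-3-yl on the carbonyl carbon gave a 4.5-fold lower number from compound 3 to compound 4 (0.65 log units; beyond the scatter), a step that can be told apart from the usual variation between repeats, whereas the same change on the core of compound 1 could not be. Set side by side, the two steps differ, so in this series the size of the change did not carry over unchanged from one core to the other: the same change on two cores in this assay, a 1.7-fold lower number (0.22 log units; within the scatter) from compound 1 to compound 2 and a 4.5-fold lower number (0.65 log units; beyond the scatter) from compound 3 to compound 4, 2.7-fold (0.43 log units) apart, beyond the scatter of two such steps. Among these compounds, this rests on only two pairs of compounds, however, and it shows neither which part of the core of compound 3 goes with the larger step nor how the change would behave on any third core.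

The compounds shown leave open whether the step on the core of compound 3 goes with the iodine atom or with the loss of the ring nitrogen, since the change swaps both at once. An unsubstituted phenyl on the same carbonyl carbon would help to separate the two, and a phenyl bearing a bromine atom, a methoxy group or an amine on each of the two cores would show how far the difference between the cores extends.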